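This account rests on a few compounds, and the source may have more. Where it says the series, first, only, none or still open, it means among the compounds named here.

Of the compounds shown here, three of this study have been measured in an assay on HEK293 cells for positive allosteric modulation of metabotropic glutamate receptor 5 (Homo sapiens), read by FLIPR; on this read-out lower numbers stand for an effect already at smaller amounts and higher numbers for an effect only at larger amounts of compound. Compound 1 `O=C(C1CCC1)N1CC(c2nc(-c3cccc(Cl)c3)no2)C1` carries a cyclobutyl on the carbonyl carbon; in this assay compound 1 reaches only the limit > 10000 nM, so no number is known for it. Compound 3 `O=S(=O)(c1ccc(Cl)cc1)N1CC(c2nc(-c3cccc(Cl)c3)no2)C1` likewise stops at the limit > 10000 nM in this assay. For the measured compounds named here, compound 2 `Cc1cccc(-c2noc(C3CN(C(=O)C4CCC(C(F)(F)F)CC4)C3)n2)c1` is the single member with a numeric result, giving 1000 nM in this assay. Compound 1 thus sits at the limit of > 10000 nM in this assay, at which 2 of the 3 values shown sit, together with compound 3, while compound 2 alone lies inside the measurable range.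

Compound 4 `COC1CCCN(C(=O)N2CC(c3nc(-c4cccc(Cl)c4)no3)C2)C1` is yet to be measured. It differs from compound 1 by 3-methoxypiperidin-1-yl in place of cyclobutyl on a carbonyl carbon. Going by the values given here, no measured pair in the set differs in a single place, so the size of this step cannot be read from the data. Because two of three values sit at the limit of > 10000 nM in this assay, at which 2 of the 3 values shown sit, the expectation is that compound 4 remains weak. The step of an at least 1.2-fold lower number from compound 1 to compound 4 (0.09 log units; that floor lies within the scatter) is expected to be small, at most a modest gain. Compound 4 is estimated at 8000 nM, within 2000 nM to 30000 nM, with a fair chance that only a limit is reported again.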

Compound 4, half-maximal effective concentration: > 10000 nM
Compound 4: only a limit was reported; the forecaster's own chance of this, stated with the estimate: 55%; middle value at least 1.2-fold (0.09 log units) away from the limit.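

For the compounds shown here, the limits reached by compound 1 and compound 4 in this assay leave no step between the two readable. The compounds shown leave open whether 3-methoxypiperidin-1-yl and cyclobutyl on a carbonyl carbon differ at all, and which single change could bring such compounds to a numeric result.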